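The compounds below may be only part of what the source reports. "The series", "measured", "known", "first", "only" and "open" are said of these compounds alone.

Compound 1 `O=C(O)CSC(CC(=O)c1ccccc1)C(=O)O`: 15000 nM
Compound 2 `CC(C)c1ccc(C(=O)CC(SCC(=O)O)C(=O)O)cc1`: 3330 nM
Compound 3 `CC(C)(C)c1ccc(C(=O)CC(SCC(=O)O)C(=O)O)cc1`: 1390 nM

These values come from a functional assay on HeLa cells (Homo sapiens); a higher number here means a weaker inhibitor, a lower number a stronger inhibitor. Compound 3 stands lowest of the three: compound 2 sits nearest, with a 2.4-fold lower number from compound 2 to compound 3 (0.38 log units; beyond the scatter), and compound 1 furthest, with an 11-fold lower number from compound 1 to compound 3 (1.03 log units; beyond the scatter). Compound 4 `O=C(O)CSC(CC(=O)c1ccc(Cl)cc1)C(=O)O` has not been measured; compared with compound 3 the change is chloro in place of tert-butyl on an aromatic carbon. For the measured compounds named here, the steps that bear on this are those that built up the group now leaving, an 11-fold lower number from compound 1 to compound 3 (1.03 log units; beyond the scatter) and a 4.5-fold lower number from compound 1 to compound 2 (0.65 log units; beyond the scatter), both lowering the number as a larger group replaced hydrogen. Chloro brings a single heavy atom, so compound 4 is expected to show a higher number, a 3.2-fold higher number from compound 3 to compound 4 (0.51 log units; beyond the scatter), landing between the values of compound 1 and compound 3. Compound 4 is estimated at 4500 nM, within 1500 nM to 14000 nM.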

Compound 4, half-maximal inhibitory concentration: 17300 nM
Compound 4: middle estimate off by 3.8-fold (0.58 log units), on the low side; the whole stated range lies below it.
By their numbers in this assay, from the lowest: compound 3; then compound 2; then compounds 1 and 4 (each within the scatter of the next).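

In this assay, the step of a 1.2-fold higher number from compound 1 to compound 4 (0.06 log units; within the scatter) shows that putting chloro on this aromatic carbon gives no gain over hydrogen, so replacing hydrogen here does not by itself lower the number. The steps of a 5.2-fold higher number from compound 2 to compound 4 (0.72 log units; beyond the scatter) and a 12-fold higher number from compound 3 to compound 4 (1.10 log units; beyond the scatter) show how much is lost when chloro takes the place of isopropyl or tert-butyl, which ties the gain to those two carbon groups among the groups tested. Nothing at hand explains this difference.

As far as these compounds go, it remains open whether a smaller carbon group such as methyl would lower the number as isopropyl and tert-butyl do. An amine or a methoxy group at this position could also behave like those groups or like chloro.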